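From an Inactive Amide Trio to a Methylsulfonyl Analogue

The source may hold more compounds than are shown below. What is called first, only, known or untested is meant among the compounds shown, and "the series" means these compounds.

Compound 1 `O=C(Nc1ccc(Cl)c(-c2nnc3c(Cl)cccn23)c1)c1ccccn1`, in a functional assay on AN3-CA cells (Homo sapiens) for antiproliferative activity, read by MTT assay, with a stated time of 72 h; on this read-out lower numbers stand for stronger inhibition and higher numbers for weaker inhibition: > 100000 nM, a limit of the assay.
Compound 2 `O=C(Nc1ccc(Cl)c(-c2nnc3c(Cl)cccn23)c1)c1ccc(Cl)cc1`, in this assay: > 100000 nM, a limit of the assay.
Compound 3 `Cc1cc(Cl)ccc1C(=O)Nc1ccc(Cl)c(-c2nnc3c(Cl)cccn23)c1`, in this assay: > 100000 nM, a limit of the assay.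

Compound 3 stands exactly where its two companions stand: every value shown sits at the limit of > 100000 nM in this assay, at which 3 of the 3 values shown sit, so for compound 3 only a limit is known and no number. Compound 4 `CS(=O)(=O)c1cccc(C(=O)Nc2ccc(Cl)c(-c3nnc4c(Cl)cccn34)c2)c1` differs from compound 3 by 3-(methylsulfonyl)phenyl in place of 4-chloro-2-methylphenyl on a carbonyl carbon. The measured steps that bear on the same carbonyl position are a step that the two limits leave unreadable from compound 1 to compound 3 and a step that the two limits leave unreadable from compound 2 to compound 3, and the step that the two limits leave unreadable from compound 1 to compound 2 is of the same kind; none of them has a readable size, so they give no direction for this assay. With all three measured values at the limit, the step is expected to stay unreadable or at most modest; the step expected is a step that the limit leaves unreadable from compound 3 to compound 4. Compound 4 is therefore estimated at 150000 nM in this assay, with a range from 30000 nM to 1000000 nM, and it is expected most likely to be reported only as a limit.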

Compound 4, half-maximal inhibitory concentration: > 100000 nM
Compound 4: a limit, no number (the forecaster's own chance of this, stated with the estimate: 85%); the middle value lies beyond the limit too.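

For the compounds shown here, all four values are limits of the assay, so no step among compound 1, compound 2, compound 3 and compound 4 can be read. The compounds shown leave open whether any group on the carbonyl carbon gives a measurable value in this assay at all.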